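Dienone aryl series: bromo placement, cytotoxicity notes

A few compounds are considered here, and "the series" means these few. Any claim that something is new, unique, unknown or untested is made for them only; others in the source may bear on it.

Measured compounds:
compound 1 `CC1=C(/C=C/C(=O)/C=C/c2ccc(Br)cc2)C(C)(C)CCC1` — 10400 nM
compound 2 `CC1=C(/C=C/C(=O)/C=C/c2ccc(C)cc2)C(C)(C)CCC1` — 19200 nM

In a functional assay on IMR-32 cells (Homo sapiens) for cytotoxicity, read by sulforhodamine B assay, with a stated time of 48 h (on this read-out higher numbers stand for weaker inhibition and lower numbers for stronger inhibition), compound 2 gives 19200 nM. Only compound 1 stands beside it, and the two numbers are not separated: a 1.8-fold higher number from compound 1 to compound 2 (0.27 log units; within the scatter). Within the data shown here, the series so far therefore shows no change beyond the scatter.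

Compound 3 `CC1=C(/C=C/C(=O)/C=C/c2ccccc2Br)C(C)(C)CCC1` is not yet measured. Relative to compound 2 it carries 2-bromophenyl in place of 4-methylphenyl on a double-bonded chain carbon bound to a double-bonded chain carbon. Among the measured compounds shown here, the one measured step that bears on this exchange is the swap of methyl for bromo on the aromatic carbon, a 1.8-fold higher number from compound 1 to compound 2 (0.27 log units; within the scatter), which stayed within the scatter. For the measured compounds named here, no measured pair addresses moving the bromine to another ring carbon, so nothing in the data points to a step in either direction.

For compound 3 the expected step in this assay is a 1.5-fold lower number from compound 2 to compound 3 (0.17 log units; within the scatter), nothing beyond the scatter. The estimate for compound 3 is 13000 nM, with a range of 5000 nM to 35000 nM, the width reflecting the unmeasured change of ring position.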

Compound 3, half-maximal inhibitory concentration: 16300 nM
Estimate against measurement, compound 3: 1.3-fold (0.10 log units) below; the range from low to high includes it.
By their numbers in this assay, from the lowest: compounds 1, 3 and 2 (each within the scatter of the next).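

In this assay, among these compounds, the change of ring position for the bromine gives a 1.6-fold higher number from compound 1 to compound 3 (0.20 log units; within the scatter) and provides the first reading on placement: 2-bromophenyl and 4-bromophenyl are not separated on this read-out. The exchange of 4-methylphenyl for 2-bromophenyl gives a 1.2-fold lower number from compound 2 to compound 3 (0.07 log units; within the scatter) and shows that changing the substituent and its ring position together also produces no step beyond the scatter. No further data are available to explain the result.

On these data alone, all three compounds keep the shared core and differ only in the aryl group, so it remains open whether an amine or a carboxylic acid on that ring would give a step beyond the scatter. Also open, as far as these compounds go, is whether a longer chain in place of the double-bonded chain carbons would move the number.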